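The source may report more compounds than this note shows. Statements on the series, on what has been measured and on what is new or still open speak of the compounds shown alone.

Compound 1 `CCCCCC(=O)c1ccc(OCCCN2CCN(C(=O)[C@@H](CC(C)C)NC(=O)OC(C)(C)C)CC2)cc1`: 4470 nM
Compound 2 `CC(C)(C)[C@@H](N)C(=O)N1CCN(CCCOc2ccc(C(=O)C3CC3)cc2)CC1`: 19100 nM

In an assay for binding affinity to histamine H2 receptor (Homo sapiens) (on this read-out higher numbers stand for weaker inhibition and lower numbers for stronger inhibition), compound 2 gives 19100 nM, the higher of the two numbers recorded so far. The nearer neighbour, compound 1, gives 4470 nM, and the gap between them lies beyond the usual scatter, so compound 1 is the stronger binder of the pair. Compound 3 `CC(C)N[C@H](C)C(=O)N1CCN(CCCOc2ccc(C(=O)C3CC3)cc2)CC1` has not yet been measured. It differs from compound 2 in a single place: 1-(isopropylamino)ethyl in place of 1-amino-2,2-dimethylpropyl on a carbonyl carbon. For the measured compounds named here, no pair of measured compounds differs by this change alone, so the data offer no anchor for its effect, and the value of compound 2 is the only guide. The step of a 1.3-fold lower number from compound 2 to compound 3 (0.10 log units; within the scatter) is expected to stay within the scatter, with no clear direction. On that basis compound 3 is estimated at 15000 nM in this assay, with a range from 5000 nM to 45000 nM.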

Compound 3, inhibition constant: 50100 nM
Compound 3: middle estimate off by 3.3-fold (0.52 log units), on the low side; measured number above the stated range.
By their numbers in this assay, from the lowest: compound 1; then compound 2; then compound 3.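

In this assay, replacing 1-amino-2,2-dimethylpropyl with 1-(isopropylamino)ethyl on a carbonyl carbon gives a modest but real change: a 2.6-fold higher number from compound 2 to compound 3 (0.42 log units; beyond the scatter). Both groups have the same heavy-atom count, the same hydrogen-bond donor and acceptor counts and no ring, so this position responds to how the same atoms are joined, not only to what they are. Nothing available accounts for the direction of this step.

The change alters the groups on the nitrogen and on the carbon chain together, so the compounds shown cannot say which part carries the step; a simpler group such as 1-aminoethyl on the same carbonyl carbon would help to separate them. Going by these compounds, how a 1-(methylamino)ethyl group or a longer chain would read at this position also remains open.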